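Lipophilicity of a Methylamino-for-Methoxy Swap on a Biaryl

The source may hold more compounds than are shown below. What is called first, only, known or untested is meant among the compounds shown, and "the series" means these compounds.

Measured so far:
- compound 1, `CC[C@@H](Nc1c(C#N)c(-c2ccc(-c3ccc(OC)cc3)cc2)nc2cnccc12)C(N)=O`: 2.7
- compound 2, `CCOc1ccccc1-c1ccc(-c2nc3cnccc3c(N)c2C#N)cc1`: 3
- compound 3, `CCOc1ccccc1-c1ccc(-c2nc3cnccc3c(C[C@H](C)C(N)=O)c2C#N)cc1`: 3

Of the compounds shown here, three sharing a common core have been read in a physicochemical assay for lipophilicity, read by HPLC, at pH 7.5; a lower number here means a more polar compound, a higher number a more lipophilic compound. Compound 1 gives the lowest of the three numbers, 2.7; compound 2 at 3 and compound 3 at 3 both lie a little higher, yet both gaps fall within the scatter, so the three are best treated as indistinguishable on these data. Among the compounds with values here, the one measured step, no change at the digits printed from compound 2 to compound 3 (within the scatter), compares two compounds that differ far from the ring of interest here, and so it does not bear on the change now considered.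

Compound 4, `CC[C@@H](Nc1c(C#N)c(-c2ccc(-c3ccccc3NC)cc2)nc2cnccc12)C(N)=O`, differs from compound 1 as follows:
2-(methylamino)phenyl in place of 4-methoxyphenyl on an aromatic carbon

Within the data shown here, no measured pair shows this kind of exchange, so the expectation rests on the groups themselves as named. Since the entering group brings one hydrogen-bond donor where the leaving group had none, compound 4 is estimated to sit somewhat lower than compound 1 in this assay, with the expected step of a number 0.20 log units lower from compound 1 to compound 4 (within the scatter) being modest and possibly within the scatter. Compound 4 is therefore estimated at 2.5, with a range from 2.1 to 2.9.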

Compound 4, distribution coefficient: 2.5
Beside the measured number, compound 4's estimate shows no gap at the digits printed; the range from low to high includes it.
By their numbers in this assay, from the lowest: compounds 4, 1, 2 and 3 (each within the scatter of the next, the first and the last beyond it).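

In this assay, within the data shown here, replacing 4-methoxyphenyl with 2-(methylamino)phenyl gives a number 0.20 log units lower from compound 1 to compound 4 (within the scatter), the first measured step at this place on the shared core, on an aromatic carbon para to a large group. The two groups match in heavy atoms and in hydrogen-bond acceptors, but the entering group carries a hydrogen-bond donor that the leaving group lacks, so this one pair shows that such an exchange at this place can leave the number within the scatter. Nothing among the data given accounts for the size of this step.

The change alters both the atom attached to the ring and where the substituent sits, so the compounds shown leave open how each part contributes, and a 2-methoxyphenyl or a 4-(methylamino)phenyl group at this place would pull the two apart. Also open, as far as these compounds go, is how far this assay could move at this place with a group further from these two, such as a carboxylic acid or a longer amine chain.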